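A few compounds are considered here, and "the series" means these few. Any claim that something is new, unique, unknown or untested is made for them only; others in the source may bear on it.

The series rests on one shared core, seen in compound 1 `O=c1c2ccccc2c(Nc2n[nH]c3ccccc23)nn1-c1ccccc1` and in compound 2 `Cc1cc(Nc2nn(Cc3ccncc3)c(=O)c3ccccc23)n[nH]1` and in compound 3 `CC(=O)Nc1ccc(Cn2nc(Nc3cc[nH]n3)c3ccccc3c2=O)cc1` alike. In a functional assay on COLO 205 cells (Homo sapiens) for cytotoxicity (a lower number here means a stronger inhibitor, a higher number a weaker inhibitor), compound 2 gives 13000 nM and is thus a weak inhibitor of these cells. For compound 1 the entry in this assay reads "not determined" (no result reported). For compound 3 the entry in this assay reads "not determined" (no result reported). Among the measured compounds shown here, compound 2 therefore carries the only number in the set and stands alone, with nothing measured to rank it against.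

Compound 4 `Cc1cc(Nc2nn(Cc3csc(C)n3)c(=O)c3ccccc23)n[nH]1` is compound 2 altered in a single place: 2-methyl-1,3-thiazol-4-yl in place of pyridin-4-yl on a saturated chain carbon bound to an aromatic nitrogen. For the measured compounds named here, no two measured compounds differ in this way, so the change has no precedent in the data. With compound 2 at 13000 nM as the only anchor, the step in this assay from compound 2 to compound 4 is expected to be small, a 1.3-fold lower number from compound 2 to compound 4 (0.11 log units; within the scatter) and within the usual scatter, with no direction that the data support. Compound 4 is therefore expected to give about 10000 nM in this assay with a range from 3000 nM to 40000 nM around that estimate.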

Compound 4, half-maximal inhibitory concentration: > 30000 nM
Compound 4 was reported as a limit; the forecaster's own chance of this, stated with the estimate: 20%; middle value at least 3.0-fold (0.47 log units) away from the limit.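

In this assay compound 4 gives > 30000 nM, which is a limit of the assay and not a number. Putting 2-methyl-1,3-thiazol-4-yl in place of pyridin-4-yl on a saturated chain carbon bound to an aromatic nitrogen gives an at least 2.3-fold higher number from compound 2 to compound 4 (0.36 log units; beyond the scatter), so this position now has one readable step, and that step runs toward weaker inhibition. Only the lower bound of this step can be read, because the value of compound 4 is censored: the limit of > 30000 nM in this assay, at which 1 of the 4 values shown sits.

As far as these compounds go, whether the step comes from the change of ring or from its methyl stays open, and 1,3-thiazol-4-yl without the methyl would separate the two. Also open, from the compounds shown here alone, is whether a plain phenyl or pyridin-3-yl on the same chain carbon would stay near compound 2 or move further from it.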